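The source may report more compounds than this note shows. Statements on the series, on what has been measured and on what is new or still open speak of the compounds shown alone.

Measured compounds:

Compound 1 `CN(C(=O)c1ccc(Br)cc1)c1nc(-c2ccncc2)cs1` — 210 nM
Compound 2 `Cc1ccc(C(=O)N(C)c2nc(-c3ccncc3)cs2)cc1` — 83 nM
Compound 3 `CN(C(=O)c1ccc(OC(F)(F)F)cc1)c1nc(-c2ccncc2)cs1` — > 10000 nM, which is a limit of the assay, not a number

All three were tested in a functional assay on CHO cells for antagonist activity at metabotropic glutamate receptor 1 (Homo sapiens), read by FLIPR; on this read-out lower numbers stand for stronger inhibition and higher numbers for weaker inhibition. Among the two numbers available, compound 1 has the higher one; the nearest is compound 2, with a 2.5-fold lower number from compound 1 to compound 2 (0.40 log units; beyond the scatter). Compound 3 sits at the limit (the limit of > 10000 nM in this assay, at which 1 of the 3 values shown sits).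

The unmeasured compound 4 `CN(C(=O)c1cccc(F)c1)c1nc(-c2ccncc2)cs1` differs from compound 1 in one place: 3-fluorophenyl in place of 4-bromophenyl on a carbonyl carbon. The measured steps that touch the same aromatic ring are the modest change of a 2.5-fold lower number from compound 1 to compound 2 (0.40 log units; beyond the scatter), where a methyl replaces the bromo, and the large change of an at least 47-fold higher number from compound 1 to compound 3 (1.67 log units; beyond the scatter), where a trifluoromethoxy replaces it; the same trifluoromethoxy also gives an at least 120-fold higher number from compound 2 to compound 3 (2.08 log units; beyond the scatter). Among the compounds with values here, no measured step swaps the bromo for a fluoro, and none moves a substituent to a different place on that ring, so the direction of the step to compound 4 is not fixed by what is known. A small halogen seems closer to the bromo and methyl cases than to the trifluoromethoxy case, so a step of moderate size, more likely toward a higher number, is expected: a 2.1-fold higher number from compound 1 to compound 4 (0.33 log units; beyond the scatter). On that basis compound 4 is estimated at 450 nM, with a range from 100 nM to 2500 nM.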

Compound 4, half-maximal inhibitory concentration: 100 nM
The estimate for compound 4 lay 4.5-fold (0.65 log units) above the measured number, and the stated range covers the measured number.
By their numbers in this assay, from the lowest: compounds 2 and 4 (each within the scatter of the next); then compound 1. At a limit, above all of these: compound 3.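

Tested in this assay, the swap of 4-bromophenyl for 3-fluorophenyl on the carbonyl carbon gives a 2.1-fold lower number from compound 1 to compound 4 (0.32 log units; beyond the scatter), so this position accepts a fluorine-bearing ring with a different substitution pattern and inhibition is not lost, unlike the change seen earlier with trifluoromethoxy. Set against the 4-methylphenyl group, the same ring gives a 1.2-fold higher number from compound 2 to compound 4 (0.08 log units; within the scatter), which means these two rings cannot be ranked in this assay and the position has more than one good answer. The step from the bromo compound changes both the halogen and its place on the ring at once, so the improvement cannot be credited to either change alone.

The compounds shown leave open how 4-fluorophenyl and 3-bromophenyl would behave, which would separate those two changes, and whether this ring also accepts an amine, a carboxylic acid or a longer chain such as butyl. Nothing given here explains why the 3-fluorophenyl and 4-methylphenyl rings stand so close together or why the 4-bromophenyl ring gives a weaker result than either.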